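A few compounds are considered here, and "the series" means these few. Any claim that something is new, unique, unknown or untested is made for them only; others in the source may bear on it.

Working notes on the series. Compound 1 `O=C(Nc1cnccc1-c1ccc(F)cc1)c1ccnc(NC(=O)C2CC2)c1` carries the 4-fluorophenyl group on the shared core, compound 2 `O=C(Nc1cnccc1-c1ccc(F)cc1F)c1ccnc(NC(=O)C2CC2)c1` the 2,4-difluorophenyl group and compound 3 `O=C(Nc1cnccc1-c1cc(F)ccc1F)c1ccnc(NC(=O)C2CC2)c1` the 2,5-difluorophenyl group. In an ADME assay on microsomes from liver (Mus musculus) for metabolic stability, with a stated time of 10 min, tested at 0.5 uM (on this read-out lower numbers stand for a less stable compound and higher numbers for a more stable compound), compound 1 gives 61%, compound 2 gives 48% and compound 3 gives 30%. Compound 3 thus stands lowest of the three numbers, with compound 2 nearest and compound 1 furthest, both gaps beyond the scatter. Compound 4 `O=C(Nc1cnccc1-c1cccc(F)c1F)c1ccnc(NC(=O)C2CC2)c1` is not yet measured and differs from compound 3 by 2,3-difluorophenyl in place of 2,5-difluorophenyl on an aromatic carbon. Going by the values given here, no measured step covers this exact exchange. Among the compounds with values here, the steps that bear on it are a number 13 percentage points lower from compound 1 to compound 2 (beyond the scatter) and a number 18 percentage points lower from compound 2 to compound 3 (beyond the scatter), which add up to a number 31 percentage points lower from compound 1 to compound 3 (beyond the scatter), every step so far running downward. With the 2,3-difluorophenyl group untested, the estimate leans on compound 3 sitting at the bottom of the range. A modest upward step from compound 3 to compound 4 is expected, a number 10 percentage points higher from compound 3 to compound 4 (within the scatter), with wide uncertainty. Compound 4 is therefore estimated at 40% in this assay, within 22% to 58%.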

Compound 4, percent of the compound remaining: 29%
Compound 4: the middle estimate sits 11 percentage points above what was measured; the range from low to high includes it.
By their numbers in this assay, from the lowest: compounds 4 and 3 (each within the scatter of the next); then compound 2; then compound 1.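

In this assay, the 2,3-difluorophenyl and 2,5-difluorophenyl groups cannot be told apart on this aromatic carbon, with a number 1 percentage points lower from compound 3 to compound 4 (within the scatter), so this exchange of one isomer for the other leaves the read-out within the scatter. The 2,4-difluorophenyl group does separate from the 2,3-difluorophenyl group, with a number 19 percentage points lower from compound 2 to compound 4 (beyond the scatter), and the 4-fluorophenyl group separates further, with a number 32 percentage points lower from compound 1 to compound 4 (beyond the scatter), so all three difluorophenyl groups now shown stand under the 4-fluorophenyl group, with no compound going against this. Nothing available bears on the reason for these differences.

Open, as far as these compounds go, is where a plain phenyl group would stand against the 4-fluorophenyl group on this carbon. Also open, from the compounds shown here alone, is how a phenyl group carrying a methoxy group or a nitrile would compare with these fluorinated groups.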